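Predicting compound 4 from two measured pairs

The source may report more compounds than this note shows. Statements on the series, on what has been measured and on what is new or still open speak of the compounds shown alone.

Compound 1 `Cc1ccc(S(=O)(=O)c2nc3ccccc3nc2Nc2cccc(O)c2)cc1`: 3810 nM
Compound 2 `Cc1ccc(S(=O)(=O)c2nc3ccccc3nc2Nc2ccc(F)cc2)cc1`: 10500 nM
Compound 3 `O=S(=O)(c1ccc(Br)cc1)c1nc2ccccc2nc1Nc1cccc(O)c1`: 540 nM

Of the compounds shown here, three have been tested in a functional assay on HCT-116 cells (Homo sapiens) for cytotoxicity, read by MTT assay, with a stated time of 72 h; on this read-out higher numbers stand for weaker inhibition and lower numbers for stronger inhibition. Compound 3 has the lowest number of the three. Compound 2 differs from compound 1 by the change (4-fluorophenyl in place of 3-hydroxyphenyl on a nitrogen on an aromatic ring), and this gave a 2.8-fold higher number from compound 1 to compound 2 (0.44 log units; beyond the scatter). Compound 3 differs from compound 1 by the change (bromo in place of methyl on an aromatic carbon), which gave a 7.1-fold lower number from compound 1 to compound 3 (0.85 log units; beyond the scatter).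

Compound 4 `O=S(=O)(c1ccc(Br)cc1)c1nc2ccccc2nc1Nc1ccc(F)cc1` has not yet been measured. It differs from compound 3 by the change (4-fluorophenyl in place of 3-hydroxyphenyl on a nitrogen on an aromatic ring). Among the measured compounds shown here, this is the same change as the one from compound 1 to compound 2, made at the same place, on a different core. The two cores differ by the change (bromo in place of methyl on an aromatic carbon).

The step from compound 3 to compound 4 in this assay is expected to be about as large as the earlier one: a 2.8-fold higher number from compound 3 to compound 4 (0.44 log units; beyond the scatter), because the same change gave a 2.8-fold higher number from compound 1 to compound 2 (0.44 log units; beyond the scatter). This rests on a single measured pair, so the range is kept wide. Compound 4 is therefore estimated at 1500 nM, between 700 nM and 3500 nM.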

Compound 4, half-maximal inhibitory concentration: 1670 nM
Estimate against measurement, compound 4: 1.1-fold (0.05 log units) below, and the stated range covers the measured number.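

In this assay, placing 4-fluorophenyl where 3-hydroxyphenyl stood on the bromo core gave a 3.1-fold higher number from compound 3 to compound 4 (0.49 log units; beyond the scatter), and this step matches the one seen on the methyl core: the same change on two cores in this assay, a 2.8-fold higher number (0.44 log units; beyond the scatter) from compound 1 to compound 2 and a 3.1-fold higher number (0.49 log units; beyond the scatter) from compound 3 to compound 4, 1.1-fold (0.05 log units) apart, within the scatter of two such steps

Read the other way, bromo in place of methyl gave a 6.3-fold lower number from compound 2 to compound 4 (0.80 log units; beyond the scatter), and this step matches its earlier counterpart: the same change on two cores in this assay, a 7.1-fold lower number (0.85 log units; beyond the scatter) from compound 1 to compound 3 and a 6.3-fold lower number (0.80 log units; beyond the scatter) from compound 2 to compound 4, 1.1-fold (0.05 log units) apart, within the scatter of two such steps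

Across these compounds, each change therefore moved the number by much the same amount whichever form the other site took, but this rests on a single set of cores in a single assay, so it does not show that the same would hold on other cores, nor does it explain why either change moves the number.

The 3-hydroxyphenyl and 4-fluorophenyl groups differ in more than one respect, so these compounds cannot tell which difference matters. From the compounds shown here alone, it also remains open whether a plain phenyl or an aminophenyl on that nitrogen, or chloro in place of bromo, would fit the same pattern.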